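Swapping the Aryl Group on Compound 1

The source may report more compounds than this note shows. Statements on the series, on what has been measured and on what is new or still open speak of the compounds shown alone.

Compound 1 `COc1cc2c(Oc3ccc(NC(=O)c4nn(-c5ccccc5C(F)(F)F)c(=O)cc4C)cc3F)ccnc2cc1OCCCN1CCCC1` stands at one of two numbers that cannot be told apart: in a functional assay on U-87MG ATCC cells (Homo sapiens) for inhibition, read by MTT assay, with a stated time of 72 h (a lower number here means a stronger inhibitor, a higher number a weaker inhibitor), compound 1 gives 1010 nM, while compound 2 `COc1cc2c(Oc3ccc(NC(=O)c4nn(-c5ccccc5C(F)(F)F)c(=O)cc4C)cc3F)ccnc2cc1OCCCN1CCN(C)CC1` gives 1170 nM. Among the compounds with values here, the single measured step, a 1.2-fold higher number from compound 1 to compound 2 (0.06 log units; within the scatter), swaps the chain end and lies within the scatter. Compound 3 `COc1ccc(-n2nc(C(=O)Nc3ccc(Oc4ccnc5cc(OCCCN6CCCC6)c(OC)cc45)c(F)c3)c(C)cc2=O)cc1` changes a different part, the aryl group on the ring nitrogen: 4-methoxyphenyl in place of 2-(trifluoromethyl)phenyl on an aromatic nitrogen. Within the data shown here, no measured step touches this position, so nothing here predicts a direction. For compound 3 the expected step is a 1.1-fold higher number from compound 1 to compound 3 (0.04 log units; within the scatter), none beyond the scatter. Compound 3 is therefore estimated at 1100 nM, within 300 nM to 4500 nM.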

Compound 3, half-maximal inhibitory concentration: 2960 nM
Compound 3: the middle estimate sits 2.7-fold (0.43 log units) below what was measured; low and high end bracket the measured number.
By their numbers in this assay, from the lowest: compounds 1 and 2 (each within the scatter of the next); then compound 3.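

The aryl group on the ring nitrogen is a position where a single change can move the result beyond the scatter in this assay: 4-methoxyphenyl in place of 2-(trifluoromethyl)phenyl gives a 2.9-fold higher number from compound 1 to compound 3 (0.47 log units; beyond the scatter). The chain-end swap between compound 1 and compound 2 did not do this. Nothing available explains the shift.

The compounds shown leave open whether the loss of trifluoromethyl or the gain of methoxy accounts for the step. A plain phenyl group on the same nitrogen would help separate the two.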